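Removing One Methoxy Group from Compound 2

The source may hold more compounds than are shown below. What is called first, only, known or untested is meant among the compounds shown, and "the series" means these compounds.

Compound 1 `FC(F)(F)c1ccc(C2CC(c3ccc4c(c3)OCCO4)=NN2c2ccccc2)cc1`. In a functional assay on WM 266-4 cells (Homo sapiens) for antiproliferative activity, read by MTT assay, with a stated time of 24 h (a higher number here means a weaker inhibitor of growth, a lower number a stronger inhibitor of growth), compound 1 gives only a limit, > 100000 nM.
Compound 2 `COc1ccc(C2CC(c3ccc4c(c3)OCCO4)=NN2c2ccccc2)cc1OC`, in this assay compound 2 gives 2160 nM.

Compound 2 holds the only number shown in this assay; the other value is a limit. Compound 3 `COc1ccc(C2CC(c3ccc4c(c3)OCCO4)=NN2c2ccccc2)cc1` differs from compound 2 by hydrogen in place of methoxy on an aromatic carbon. Among the measured compounds shown here, the one measured step that bears on this is an at least 46-fold lower number from compound 1 to compound 2 (1.66 log units; beyond the scatter), but that step exchanges the whole aryl group on the saturated ring carbon, whereas the present change removes a single methoxy from the 3,4-dimethoxyphenyl to leave 4-methoxyphenyl. For the measured compounds named here, no measured step separates the two methoxy groups from each other, so their individual weight is unknown. The expectation is that compound 3 loses some of what the 3,4-dimethoxyphenyl gained and shows a higher number than compound 2, a step of a 2.1-fold higher number from compound 2 to compound 3 (0.32 log units; beyond the scatter), though a result within the scatter is also plausible. Compound 3 is therefore estimated at 4500 nM, with a range from 1500 nM to 14000 nM.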

Compound 3, concentration for 50% growth inhibition: > 100000 nM
Compound 3: no number, only a limit; the forecaster's own chance of this, stated with the estimate: 5%; at least 22-fold (1.34 log units) between middle value and limit.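

In this assay hydrogen in place of methoxy on an aromatic carbon, ortho to a methoxy group, gives an at least 46-fold higher number from compound 2 to compound 3 (1.66 log units; beyond the scatter) and so shows that this single methoxy, and not only the exchange of the whole aryl group, decides whether a number is reached. Compound 3 gives only the limit > 100000 nM and the step between compound 1 and compound 3 cannot be read, since both of its values are limits. Among the compounds shown, 4-methoxyphenyl is no better placed than 4-(trifluoromethyl)phenyl, and only 3,4-dimethoxyphenyl gives a number: the limit of > 100000 nM in this assay, at which 2 of the 3 values shown sit.

From the compounds shown here alone, how 3-methoxyphenyl would behave on the shared core stays open. So does whether a hydroxy or an ethoxy group in place of the lost methoxy would keep a number in this assay at all.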